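From Ethoxy to Butoxy: An Expected Step in Cytotoxicity

A few compounds are considered here, and "the series" means these few. Any claim that something is new, unique, unknown or untested is made for them only; others in the source may bear on it.

Compound 3 `CCOc1ccccc1C[C@H]1COC(=O)[C@@H]1Cc1ccc(Cl)c(Cl)c1` holds the lowest of the three numbers recorded in a functional assay on HL-60 cells (Homo sapiens) for cytotoxicity, read by WST assay, with a stated time of 48 h (a higher number here means that more compound is needed for the effect, a lower number that less compound is needed), where compound 3 gives 15000 nM. Compound 1 `O=C1OC[C@H](Cc2ccccc2)[C@H]1Cc1ccc(Cl)c(Cl)c1`, which carries hydrogen on the aromatic carbon in question, gives 19000 nM in this assay, and compound 2 `O=C1OC[C@H](Cc2ccccc2O)[C@H]1Cc1ccc(Cl)c(Cl)c1`, with a hydroxy group there, gives 33000 nM. The step of a 1.3-fold lower number from compound 1 to compound 3 (0.10 log units; within the scatter) lies within the scatter, whereas a 2.2-fold lower number from compound 2 to compound 3 (0.34 log units; beyond the scatter) counts as a modest gain. Compound 4 `CCCCOc1ccccc1C[C@H]1COC(=O)[C@@H]1Cc1ccc(Cl)c(Cl)c1` differs from compound 3 by ethyl in place of hydrogen on a saturated chain carbon, two bonds along the chain from an oxygen on an aromatic ring; cut one bond further out, the change reads ethoxy to butoxy. Among the compounds with values here, the only steps that bear on it are those leading into compound 3: the move from hydroxy to ethoxy lowered the number modestly, and the move from hydrogen to ethoxy did nothing beyond the scatter, so a further ethyl on that chain is expected to bring little change in this assay, most likely none that stands out of the scatter. Compound 4 is therefore expected to give about 12000 nM, with a range from 5000 nM to 30000 nM. The step of a 1.3-fold lower number from compound 3 to compound 4 (0.10 log units; within the scatter) that this estimate means is expected to lie within the scatter.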

Compound 4, half-maximal effective concentration: 10000 nM
Estimate against measurement, compound 4: 1.2-fold (0.08 log units) above; the range from low to high includes it.
By their numbers in this assay, from the lowest: compounds 4, 3, 1 and 2 (each within the scatter of the next, the first and the last beyond it).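

In this assay, going from ethoxy to butoxy gives a 1.5-fold lower number from compound 3 to compound 4 (0.18 log units; within the scatter) for this change, so the added ethyl on the saturated chain does not separate the two ethers. Set against hydrogen on the aromatic carbon, butoxy also gives only a 1.9-fold lower number from compound 1 to compound 4 (0.28 log units; within the scatter), and neither ether has therefore moved clear of the compound that carries hydrogen there. Butyl in place of hydrogen on the oxygen stands out only against the hydroxy compound, with a 3.3-fold lower number from compound 2 to compound 4 (0.52 log units; beyond the scatter), a modest step.

On these data alone, whether hexyloxy, or an amine or a carboxylic acid in place of the butoxy, would carry the number beyond the scatter stays open. The compounds shown also leave open whether these small steps would hold in any other cell line, and nothing offered here accounts for them.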